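Aryl change on a shared core: expectation for compound 4

A few compounds are considered here, and "the series" means these few. Any claim that something is new, unique, unknown or untested is made for them only; others in the source may bear on it.

Compound 1 `Cc1ccc(N2CCN(C(=S)N/N=C3\C(=O)Nc4ccc(Cl)cc43)CC2)cc1` gives 6390 nM in a functional assay on HCT-116 cells (Homo sapiens) for inhibition, read by MTT assay, with a stated time of 72 h; a lower number here means a stronger inhibitor, a higher number a weaker inhibitor.
Compound 2 `Cc1ccccc1N1CCN(C(=S)N/N=C2\C(=O)Nc3ccc(Cl)cc32)CC1` gives 4910 nM in this assay.
Compound 3 `Cc1ccc(N2CCN(C(=S)N/N=C3\C(=O)Nc4ccc(Cl)cc43)CC2)c(C)c1` gives 7180 nM in this assay.

Compound 3 carries the highest of the three numbers, but its steps to the other two do not leave the scatter: a 1.1-fold higher number from compound 1 to compound 3 (0.05 log units; within the scatter) and a 1.5-fold higher number from compound 2 to compound 3 (0.17 log units; within the scatter). The remaining pair is likewise flat, a 1.3-fold lower number from compound 1 to compound 2 (0.11 log units; within the scatter), so the three compounds cannot be ordered on these numbers.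

Compound 4 `O=C1Nc2ccc(Cl)cc2/C1=N/NC(=S)N1CCN(c2ccccc2Cl)CC1` differs from compound 3 in a single place: 2-chlorophenyl in place of 2,4-dimethylphenyl on an amine nitrogen in a ring. The three measured steps are the ones that bear on this, since each of them also alters only the aryl group on the same ring nitrogen, either by moving a methyl or by adding one, and none of them moved the number beyond the scatter. The change to compound 4 removes both methyls and brings in a chlorine instead, which is a somewhat larger alteration than any measured step, so a modest drift in either direction remains possible; still, the expectation is for no step beyond the scatter, a 1.3-fold lower number from compound 3 to compound 4 (0.12 log units; within the scatter). Compound 4 is therefore estimated at 5500 nM in this assay, within a range of 2500 nM to 12000 nM.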

Compound 4, half-maximal inhibitory concentration: 4910 nM
Estimate against measurement, compound 4: 1.1-fold (0.05 log units) above; measured number inside the range.
By their numbers in this assay, from the lowest: compounds 2, 4, 1 and 3 (each within the scatter of the next).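

In this assay, the aryl group on the ring nitrogen now carries a chlorine, whereas compound 1, compound 2 and compound 3 carry only methyl groups there, and this change leaves the number within the scatter in all three comparisons: chloro in place of methyl gives no change at the digits printed from compound 2 to compound 4 (within the scatter), 2-chlorophenyl in place of 2,4-dimethylphenyl gives a 1.5-fold lower number from compound 3 to compound 4 (0.17 log units; within the scatter), and 2-chlorophenyl in place of 4-methylphenyl gives a 1.3-fold lower number from compound 1 to compound 4 (0.11 log units; within the scatter). The flat picture at this position therefore extends beyond methyl groups to this chloro compound, and the four compounds still cannot be ordered on these numbers. No evidence is available to explain why the numbers stay so close.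

The compounds shown leave open whether a methoxy group, a nitrile, a carboxylic acid or an amine on this phenyl ring would produce a step beyond the scatter. They also leave open whether a saturated ring or a longer chain on the ring nitrogen in place of the aryl group would do so.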